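The source may hold more compounds than are shown below. What is called first, only, known or untested is meant among the compounds shown, and "the series" means these compounds.

Measured in an ADME assay on BaF3 cells (Mus musculus) for antiproliferative activity, read by CCK-8 assay, with a stated time of 72 h; on this read-out lower numbers stand for stronger inhibition of growth and higher numbers for weaker inhibition of growth:
- compound 1 `CN1CCN(Cc2ccc(NC(=O)CCSc3ccc4c(/C=C/c5ccccn5)n[nH]c4c3)cc2C(F)(F)F)CC1`: 2480 nM
- compound 2 `O=C(NCCCSc1ccc2c(/C=C/c3ccccn3)n[nH]c2c1)c1cccc(C(F)(F)F)c1`: 980 nM
- compound 3 `Cc1n[nH]c2cc(SCCC(=O)Nc3ccc(CN4CCN(C)CC4)c(C(F)(F)F)c3)ccc12`: 3900 nM

Compound 3, at 3900 nM, cannot be told apart from compound 1, at 2480 nM. The number of compound 2, 980 nM, is lower than both of these.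

Compound 4 `CN1CCN(Cc2ccc(NC(=O)CCSc3ccc4c(-c5ccccc5)n[nH]c4c3)cc2C(F)(F)F)CC1` has phenyl in place of methyl on an aromatic carbon of the five-membered aromatic ring with 2 nitrogen, (phenyl in place of methyl on an aromatic carbon).

Within the data shown here, only one measured step touches this carbon: a 1.6-fold higher number from compound 1 to compound 3 (0.20 log units; within the scatter), with methyl in place of 2-(pyridin-2-yl)ethenyl. Among the measured compounds shown here, that exchange between methyl and a much larger group stayed within the scatter, and it is the only guide available, since no measured compound carries phenyl here. Compound 2 differs from the others in more than one place, so it says little about this carbon. No shift beyond the scatter is therefore expected in this assay, and a number close to those of compound 1 and compound 3 seems most likely. The expected change is a 1.6-fold lower number from compound 3 to compound 4 (0.19 log units; within the scatter). For compound 4 the estimated value is 2500 nM, with an expected range from 900 nM to 6500 nM.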

Compound 4, concentration for 50% growth inhibition: 600 nM
Compound 4: middle estimate off by 4.2-fold (0.62 log units), on the high side, and the stated range ends above it.
By their numbers in this assay, from the lowest: compounds 4 and 2 (each within the scatter of the next); then compounds 1 and 3 (each within the scatter of the next).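

In this assay, this carbon of the five-membered aromatic ring turns out to be able to move the number: phenyl in place of methyl gave a 6.5-fold lower number from compound 3 to compound 4 (0.81 log units; beyond the scatter), whereas the exchange between methyl and 2-(pyridin-2-yl)ethenyl had stayed within the scatter. Phenyl in place of 2-(pyridin-2-yl)ethenyl also gave a 4.1-fold lower number from compound 1 to compound 4 (0.62 log units; beyond the scatter), so among these three compounds the outcome depends on which group sits on this carbon, and the two groups larger than methyl do not give the same number. Nothing measured on these compounds bears on what lies behind this difference.

The compounds shown leave open whether the lower number belongs to phenyl alone or would also hold for a phenyl carrying a methoxy group or a fluorine, or for a pyridin-2-yl ring attached directly to this carbon. They also leave open whether phenyl on this carbon would give a step of similar size with the different side chain of compound 2, which so far is known only with 2-(pyridin-2-yl)ethenyl here.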